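Bromo in place of hydrogen on compound 3

A few compounds are considered here, and "the series" means these few. Any claim that something is new, unique, unknown or untested is made for them only; others in the source may bear on it.

Of the compounds shown here, three have so far been measured in a physicochemical assay for lipophilicity; a lower number here means a more polar compound, a higher number a more lipophilic compound. Compound 1 `Cc1ccc(C2=NO[C@]3(C2)C(=O)O[C@@H]2[C@H]3CC[C@H](C)[C@]3(O)C=CC(=O)[C@@]23C)cc1` gives 1.86, and compound 2 `C[C@H]1CC[C@@H]2[C@@H](OC(=O)[C@]23CC(c2ccc(C#N)cc2)=NO3)[C@]2(C)C(=O)C=C[C@@]12O` gives 1.17. Compound 3 `COc1ccc(C2C[C@@]3(ON2c2ccccc2)C(=O)O[C@@H]2[C@H]3CC[C@H](C)[C@]3(O)C=CC(=O)[C@@]23C)cc1` stands highest of the three at 3.25, beyond the scatter from both others. Compound 4 `COc1ccc(C2C[C@@]3(ON2c2ccccc2)C(=O)O[C@@H]2[C@H]3CC[C@H](C)[C@]3(O)C=CC(=O)[C@@]23C)cc1Br` departs from compound 3 in one place, bromo in place of hydrogen on an aromatic carbon, ortho to a methoxy group, turning 4-methoxyphenyl into 3-bromo-4-methoxyphenyl. Going by the values given here, only one measured step involves a change on an aromatic carbon: cyano in place of methyl gave a number 0.69 log units lower from compound 1 to compound 2 (beyond the scatter). That step exchanges different groups, so it bears on this change only loosely, though it shows that a single group on such a ring can move this assay beyond the scatter. Among the compounds with values here, no measured compound carries bromo, so the direction is an expectation without a direct precedent here. A modest rise is expected, a number 0.55 log units higher from compound 3 to compound 4 (beyond the scatter). The estimated value for compound 4 is 3.8, with an expected range of 3.45 to 4.2.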

Compound 4, partition coefficient: 3.98
For compound 4 the middle estimate is 0.18 log units below the measured one, within the range that was stated.
By their numbers in this assay, from the lowest: compound 2; then compound 1; then compound 3; then compound 4.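

In this assay, bromo in place of hydrogen on an aromatic carbon, ortho to a methoxy group, gives a number 0.73 log units higher from compound 3 to compound 4 (beyond the scatter), so this change raises the number beyond the scatter on the core of compound 3. The earlier step on an aromatic carbon, a number 0.69 log units lower from compound 1 to compound 2 (beyond the scatter), exchanged cyano for methyl and went the other way, whereas here one heavy atom enters where only hydrogen stood and the number still moves beyond the scatter. Nothing measured on these compounds accounts for the size or direction of this rise.

Whether the rise belongs to bromo alone or depends on its place ortho to a methoxy group stays open, as the compounds shown carry bromo at one place only. They also do not tell how chloro, an amine or a carboxylic acid on the same aromatic carbon would read in this assay.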